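Methyl for Chloro in a Bile Acid Receptor Series

The compounds below may be only part of what the source reports. "The series", "measured", "known", "first", "only" and "open" are said of these compounds alone.

Compound 1, `COC(=O)/C=C/c1cccc(N(Cc2ccc(-c3cccc(Cl)c3)cc2)C(=O)C(C)C)c1`: 77 nM
Compound 2, `COC(=O)/C=C/c1cccc(N(Cc2ccc(-c3cccc(C)c3)cc2)C(=O)C(C)C)c1`: 163 nM
Compound 3, `COC(=O)/C=C/c1cccc(N(Cc2ccc(-c3cccc(Cl)c3)cc2)C(=O)NC(C)C)c1`: 1400 nM

Of the compounds shown here, three have been measured in an assay on isolated protein with Bile acid receptor (Homo sapiens) as the target; on this read-out higher numbers stand for an effect only at larger amounts of compound and lower numbers for an effect already at smaller amounts. Compound 1 and compound 2 differ by methyl in place of chloro on an aromatic carbon, and this change gave a 2.1-fold higher number from compound 1 to compound 2 (0.33 log units; beyond the scatter). Compound 3 differs from compound 1 by isopropylamino in place of isopropyl on a carbonyl carbon; that change gave an 18-fold higher number from compound 1 to compound 3 (1.26 log units; beyond the scatter), and compound 3 therefore stands highest of the three in this assay.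

Compound 4, `COC(=O)/C=C/c1cccc(N(Cc2ccc(-c3cccc(C)c3)cc2)C(=O)NC(C)C)c1`, has not yet been measured. It differs from compound 3 by methyl in place of chloro on an aromatic carbon, which is the same change that separates compound 1 from compound 2, made here on the core of compound 3 rather than on the core of compound 1. The two cores differ only by the change already described between compound 1 and compound 3.

The expectation for compound 4 rests on one earlier pair. Because the same change gave a 2.1-fold higher number from compound 1 to compound 2 (0.33 log units; beyond the scatter), compound 4 is estimated to show a 2.1-fold higher number from compound 3 to compound 4 (0.32 log units; beyond the scatter) in this assay. On that basis compound 4 is expected to give 2900 nM, with a plausible range from 1400 nM to 6500 nM.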

Compound 4, half-maximal effective concentration: 1330 nM
Beside the measured number, compound 4's estimate is 2.2-fold (0.34 log units) above it; the whole stated range lies above it.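

In this assay, methyl in place of chloro gave a 1.1-fold lower number from compound 3 to compound 4 (0.02 log units; within the scatter), so this pair cannot be told apart, yet the gap between this step and the earlier one stays within what two such steps can scatter: the same change on two cores in this assay, a 2.1-fold higher number (0.33 log units; beyond the scatter) from compound 1 to compound 2 and a 1.1-fold lower number (0.02 log units; within the scatter) from compound 3 to compound 4, 2.2-fold (0.35 log units) apart, within the scatter of two such steps. The other change, isopropylamino in place of isopropyl on a carbonyl carbon, gave an 8.2-fold higher number from compound 2 to compound 4 (0.91 log units; beyond the scatter) on the methyl-bearing core, a large loss on both cores and again no measurable difference between them: the same change on two cores in this assay, an 18-fold higher number (1.26 log units; beyond the scatter) from compound 1 to compound 3 and an 8.2-fold higher number (0.91 log units; beyond the scatter) from compound 2 to compound 4, 2.2-fold (0.35 log units) apart, within the scatter of two such steps. These four compounds thus show no measurable dependence of either change on the core, but with a single pair on each core they do not show that the two steps are equal, nor that either would carry over to any other core.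

The compounds shown leave open how a fluoro or methoxy group would read on that aromatic carbon. They also leave open what a carboxylic acid in place of the methyl ester, or a longer chain on the carbonyl carbon, would do in this series.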